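Shortening the side chain: cytotoxicity notes on the series

The source may hold more compounds than are shown below. What is called first, only, known or untested is meant among the compounds shown, and "the series" means these compounds.

Compound 1 `CCCCCCCCCCn1cc(-c2nc3ccccc3cc2C)nn1` and compound 2 `CCCCCCCCCCn1cc(-c2nc3ccccc3cc2CCCC)nn1` share one core and differ by hydrogen in place of propyl on a saturated chain carbon bound to an aromatic carbon. In a functional assay on HeLa cells (Homo sapiens) for cytotoxicity, read by MTT assay, with a stated time of 24 h (on this read-out lower numbers stand for stronger inhibition and higher numbers for weaker inhibition), compound 1 gives 28.2 ug/mL. For compound 2 this assay reports only a limit, > 100 ug/mL. The step of an at least 3.5-fold lower number from compound 2 to compound 1 (0.54 log units; beyond the scatter) therefore rests on one side on a limit. Among the measured compounds shown here, two of the three values known so far sit at such a limit, (the limit of > 100 ug/mL in this assay, at which 2 of the 3 values shown sit).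

Compound 3 `CCCCCc1cc2ccccc2nc1-c1cn(-c2ccc(F)cc2)nn1` has a different core; how it differs from compound 2 is not broken down here. For compound 3 this assay again reports only a limit, > 100 ug/mL.

Compound 4 `CCc1cc2ccccc2nc1-c1cn(-c2ccc(F)cc2)nn1` is the still unmeasured analogue of compound 3, differing by hydrogen in place of propyl on a saturated chain carbon, two bonds along the chain from an aromatic carbon. This is the same kind of change as between compound 2 and compound 1, but not the same: there the saturated chain carbon is bound to an aromatic carbon, here it lies two bonds along the chain from an aromatic carbon. Given an at least 3.5-fold lower number from compound 2 to compound 1 (0.54 log units; beyond the scatter) as the only guide, a step of an at least 2.0-fold lower number from compound 3 to compound 4 (0.30 log units; that floor lies within the scatter) is expected. Compound 4 is therefore estimated to give 50 ug/mL in this assay, within 15 ug/mL to 150 ug/mL.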

Compound 4, half-maximal inhibitory concentration: > 100 ug/mL
Compound 4 gave a limit, no number; the forecaster's own chance of this, stated with the estimate: 40%; middle value at least 2.0-fold (0.30 log units) away from the limit.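

Compound 3 and compound 4 both give only a limit in this assay, and no step between them can be read: the limit of > 100 ug/mL in this assay, at which 3 of the 4 values shown sit.

The compounds shown leave open whether hydrogen in place of propyl on a saturated chain carbon, two bonds along the chain from an aromatic carbon, changes the read-out on this core at all.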